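The source may report more compounds than this note shows. Statements on the series, on what has been measured and on what is new or still open speak of the compounds shown alone.

Compound 1 `CC1(C)CCC(C)(C)c2cc(C/C=C/c3ccc(C(=O)O)cc3)ccc21` in an assay on isolated protein for binding affinity to retinoic acid receptor gamma (Homo sapiens), read by radioligand binding; a lower number here means tighter binding, a higher number weaker binding: 26 nM
Compound 2 `CCc1ccc(C2=C(/C=C/C#Cc3ccc(C(=O)O)cc3)C(C)(C)CCC2)cc1` in this assay: 36 nM

Of these two numbers, compound 2 has the higher one, yet the gap to compound 1 stays within the scatter, so the two cannot be ordered. Compound 3 `CC1=C(/C=C/C#Cc2ccc(C(=O)O)cc2)C(C)(C)CCC1` has not been measured in this assay. Its difference from compound 2 is methyl in place of 4-ethylphenyl on a double-bonded ring carbon. Among the compounds with values here, no step between measured compounds covers such a change, so the account rests on expectation alone. The remaining methyl is expected to give weaker binding, with a step of an 11-fold higher number from compound 2 to compound 3 (1.05 log units; beyond the scatter) that is expected to exceed the scatter. Compound 3 is estimated at 400 nM, in a range from 70 nM to 3000 nM.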

Compound 3, dissociation constant: 190 nM
Compound 3: the middle estimate sits 2.1-fold (0.32 log units) above what was measured; measured number inside the range.
By their numbers in this assay, from the lowest: compounds 1 and 2 (each within the scatter of the next); then compound 3.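

On the double-bonded ring carbon, the exchange of 4-ethylphenyl for methyl gives a 5.3-fold higher number from compound 2 to compound 3 (0.72 log units; beyond the scatter) in this assay, so this position responds to the group it carries. In this single pair, the larger group goes with the tighter binding, although compound 3 still binds at 190 nM without the aromatic ring. No measurement shown here explains the step.

As far as these compounds go, it remains open whether the ethyl or the aromatic ring itself accounts for the difference. A plain phenyl or a butyl chain at this carbon would help separate the two.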